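A few compounds are considered here, and "the series" means these few. Any claim that something is new, unique, unknown or untested is made for them only; others in the source may bear on it.

Compound 2 `CCc1cc(C(C)=O)c(O)cc1OCCCC(C)(C)c1nnn[nH]1` gives the higher number of the two measured compounds in an assay on isolated protein for inhibition of leukotriene B4 receptor 1 (Homo sapiens), tested at 10 uM; on this read-out higher numbers stand for more inhibition at the one concentration tested (going by the name of the read-out) and lower numbers for less inhibition: compound 2 gives 100% and stands highest of the two numbers, while compound 1 `CC(=O)c1cc(C(C)(C)C)c(OCCCCCC(C)(C)C#N)cc1O` gives 1%, a gap that lies beyond the scatter of this assay. Among the measured compounds shown here, the two compounds differ in several places at once, so no single step between them can be read from these numbers; they show only that one end of this small set gives a high number and the other a low one in this assay.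

Compound 3 `CCc1cc(C(C)=O)c(O)cc1OCCCCCn1cncn1` is the next compound to be measured in this assay. It differs from compound 2 in one place: 2-(1H-1,2,4-triazol-1-yl)ethyl in place of 1-(1H-tetrazol-5-yl)-1-methylethyl on a saturated chain carbon, three bonds along the chain from an oxygen on an aromatic ring. The group that leaves carries the one hydrogen-bond donor of the pair, the group that enters carries none. For the measured compounds named here, with no measured step of this kind to lean on, the change is expected to cost inhibition, and the step from compound 2 to compound 3 is estimated at a number 55 percentage points lower from compound 2 to compound 3 (beyond the scatter), a drop beyond the scatter. Compound 3 is therefore expected to give about 45%, with a range from 10% to 85%.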

Compound 3, a percentage reported as inhibition, at one concentration (the size of the read-out at that concentration, not a potency): 82%
Compound 3: the middle estimate sits 37 percentage points below what was measured, within the range that was stated.
By their numbers in this assay, from the lowest: compound 1; then compound 3; then compound 2.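

In this assay, among the compounds shown here, the exchange of 1-(1H-tetrazol-5-yl)-1-methylethyl for 2-(1H-1,2,4-triazol-1-yl)ethyl on a saturated chain carbon, three bonds along the chain from an oxygen on an aromatic ring, gives a number 18 percentage points lower from compound 2 to compound 3 (beyond the scatter), the first step at this position that can be read on its own. The step is modest, and compound 3, whose entering group carries no hydrogen-bond donor, still gives 82%, so in this pair a high inhibition number does not depend on the tetrazole group or on its hydrogen-bond donor. No measurement shown here bears on what lies behind this step.

This single exchange alters the ring and the chain together, so the compounds shown leave open how much of the step belongs to each, and what a carboxylic acid, an amine or a longer chain would give at this position. Each number also comes from one concentration, so they leave open whether the potency of compound 2 and that of compound 3 differ in the same direction and by a similar margin.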